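Halogen exchange on the double-bonded chain carbon of compound 1

A few compounds are considered here, and "the series" means these few. Any claim that something is new, unique, unknown or untested is made for them only; others in the source may bear on it.

Compound 1 `CCC[C@@H](OC(C)=O)C1=C(Br)/C(=C/Br)OC1=O` is the reference point of the series. Among the measured compounds shown here, in a functional assay on LNCaP cells (Homo sapiens) for cytotoxicity (on this read-out higher numbers stand for an effect only at larger amounts of compound and lower numbers for an effect already at smaller amounts), compound 1 gives 0.5 ug/mL, the lowest of the three numbers measured so far. For the measured compounds named here, compound 2 `CCCCC1=C(Br)/C(=C/Br)OC1=O` gives 7.3 ug/mL in this assay; the only single-point step measured is a 15-fold higher number from compound 1 to compound 2 (1.16 log units; beyond the scatter). Going by the values given here, compound 3 `CCC[C@@H](OC(C)=O)C1=C(Br)[C@](C)(OC)OC1=O` gives 3.6 ug/mL in this assay, a higher number than compound 1, but the two differ in more than one place and no single step connects them.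

Compound 4 `CCC[C@@H](OC(C)=O)C1=C(Br)/C(=C/I)OC1=O` differs from compound 1 by iodo in place of bromo on a double-bonded chain carbon bound to a double-bonded ring carbon. Among the compounds with values here, the one measured step, from compound 1 to compound 2, concerns the acetoxy on the saturated chain carbon, not the halogen on the double-bonded chain carbon, so it does not bear on this change. Within the data shown here, no measured pair varies the halogen at that place, and the values of compound 3 give no guidance either. With nothing to indicate a shift, compound 4 is expected to stay within the scatter of compound 1, with no change at the digits printed from compound 1 to compound 4 (within the scatter). The estimate for compound 4 in this assay is therefore 0.5 ug/mL, with a range from 0.2 ug/mL to 1.5 ug/mL.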

Compound 4, concentration for half-maximal effect: 2 ug/mL
Beside the measured number, compound 4's estimate is 4.0-fold (0.60 log units) below it, and the stated range ends below it.
By their numbers in this assay, from the lowest: compound 1; then compounds 4 and 3 (each within the scatter of the next); then compound 2.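

The place on the double-bonded chain carbon is not silent on this read-out: in this assay the exchange gives a 4.0-fold higher number from compound 1 to compound 4 (0.60 log units; beyond the scatter) with the rest of the core of compound 1 unchanged. The series now holds two single-point steps from the same reference, the other being a 15-fold higher number from compound 1 to compound 2 (1.16 log units; beyond the scatter) at the acetoxy on the saturated chain carbon, so the number responds to changes at both places, with a modest step at the halogen and a large one at the acetoxy. Nothing at hand accounts for the higher number with iodo in place of bromo.

The compounds shown carry only bromo and iodo on this double-bonded chain carbon, so two halogens give one step and no trend, and how chloro, fluoro or plain hydrogen at this place would read remains open. Also open, as far as these compounds go, is whether the halogen step holds without the acetoxy, since iodo appears here only together with that group and the butyl-bearing compound 2 carries bromo alone.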